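A few compounds are considered here, and "the series" means these few. Any claim that something is new, unique, unknown or untested is made for them only; others in the source may bear on it.

Compound 1 `COc1cccc(C(=O)Nc2cc(-c3ccccc3)nn2-c2ccccc2)c1` gives 102 nM.
Compound 2 `O=C(Nc1cc(-c2ccccc2Cl)nn1-c1ccccc1)c1ccccc1` gives 2290 nM.
Compound 3 `O=C(Nc1cc(-c2ccccc2)nn1-c1ccccc1Br)c1ccc([N+](=O)[O-])cc1` gives 61 nM.

These three numbers come from a functional assay on cells for positive allosteric modulation of metabotropic glutamate receptor 5 (Rattus norvegicus), read by calcium flux; on this read-out lower numbers stand for an effect already at smaller amounts and higher numbers for an effect only at larger amounts of compound. Among them compound 1 stands second highest: compound 3 sits close by, within the scatter, while compound 2 lies far above, beyond it. The next compound, compound 4 `O=C(Nc1cc(-c2ccccc2)nn1-c1ccccc1)C1CCCCC1`, grows out of compound 1 by one change, (cyclohexyl in place of 3-methoxyphenyl on a carbonyl carbon). Going by the values given here, no measured pair shows this kind of swap, so nothing here sets its size directly. The expectation is nonetheless a step upward, beyond the scatter, in this assay; the step from compound 1 to compound 4 is estimated at a 5.9-fold higher number from compound 1 to compound 4 (0.77 log units; beyond the scatter). Compound 4 is therefore expected to give about 600 nM, with a likely range from 150 nM to 3000 nM.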

Compound 4, half-maximal effective concentration: > 10000 nM
Compound 4 gave a limit, no number (the forecaster's own chance of this, stated with the estimate: 15%); at least 16-fold (1.22 log units) between middle value and limit.
By their numbers in this assay, from the lowest: compounds 3 and 1 (each within the scatter of the next); then compound 2. At a limit, above all of these: compound 4.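

In this assay, this position on the carbonyl carbon proves sensitive to the kind of ring it carries: cyclohexyl in place of 3-methoxyphenyl gives an at least 98-fold higher number from compound 1 to compound 4 (1.99 log units; beyond the scatter). Compound 4 gives > 10000 nM, which is a limit of the assay and not a number. So an aromatic ring here cannot simply be exchanged for a non-aromatic ring of carbon.

Going by these compounds, what stays open is whether the loss of the aromatic ring or of the methoxy oxygen matters more. On these data alone, whether a pyridine ring or a short alkyl chain in this place would keep the effect also stays open.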